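A few compounds are considered here, and "the series" means these few. Any claim that something is new, unique, unknown or untested is made for them only; others in the source may bear on it.

Measured so far in a functional assay on MV4-11 cells (Homo sapiens) for cytotoxicity, read by colorimetric assay and MTT assay, with a stated time of 3 days, tested at 20 uM; on this read-out lower numbers stand for a stronger effect and higher numbers for a weaker effect at the one concentration tested:
- compound 1 `O=C1COc2ccc(-c3[nH]c(-c4ccc(C(F)(F)F)cc4)nc3-c3ccccc3)cc2N1`: 0.6%
- compound 2 `O=C1COc2ccc(-c3nn(-c4ccc(Br)cc4)cc3-c3ccccc3)cc2N1`: 91.5%
- compound 3 `COc1ccc(-n2cc(-c3ccccc3)c(-c3ccc4c(c3)NC(=O)CO4)n2)cc1`: 59.9%

Compound 1 gives the lowest number of the three in this assay; compound 3 stands nearer to it and compound 2 furthest, both gaps beyond the scatter. Within the data shown here, the one step that can be counted, a number 31.6 percentage points lower from compound 2 to compound 3 (beyond the scatter), concerns the core of compound 2 and compound 3, not the core of compound 1, and a different change of group.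

Compound 4 `O=C1COc2ccc(-c3[nH]c(-c4ccc(Cl)cc4Cl)nc3-c3ccccc3)cc2N1` differs from compound 1 in one place: 2,4-dichlorophenyl in place of 4-(trifluoromethyl)phenyl on an aromatic carbon. Among the measured compounds shown here, no measured pair covers an exchange of this kind on the core of compound 1, so the only anchor is compound 1 itself with 0.6%, which is already a very low number on this read-out. A number cannot go meaningfully lower; the open question is whether the change weakens the effect. Absent any comparable step, the expectation is a small move upward or none beyond the scatter, with a wide margin for a larger loss.

Compound 4 is therefore expected to give about 8%, estimated within 0% to 45%, meaning an expected step of a number 7.4 percentage points higher from compound 1 to compound 4 (within the scatter).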

Compound 4, a percentage reported as activity, at one concentration (the size of the read-out at that concentration, not a potency): 41.1%
For compound 4 the middle estimate is 33.1 percentage points below the measured one; the measured number falls inside the stated range.
By their numbers in this assay, from the lowest: compound 1; then compound 4; then compound 3; then compound 2.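

In this assay the group on the aromatic carbon between two ring nitrogen atoms proves sensitive to exchange: 2,4-dichlorophenyl in place of 4-(trifluoromethyl)phenyl gives a number 40.5 percentage points higher from compound 1 to compound 4 (beyond the scatter) and so marks a large step on the core of compound 1. Among these compounds, the earlier step was read on a different core and for a different exchange, so this is the first sign that the very low number of compound 1 does not simply carry over to another substituted phenyl at this place. Nothing measured here bears on why the step is this large.

The compounds shown leave open which part of the exchange matters, since the trifluoromethyl group is lost and two chlorine atoms enter in a single step, and a phenyl carrying a single chlorine would help to separate these changes. As far as these compounds go, it also remains open how this place responds to a group of another kind, such as a phenyl carrying an amine or a carboxylic acid.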